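Benzyl ether variation on a flavonol core: methoxy to methyl

A few compounds are considered here, and "the series" means these few. Any claim that something is new, unique, unknown or untested is made for them only; others in the source may bear on it.

Compound 1, `O=c1c(OCc2ccccc2Cl)c(-c2ccccc2)oc2cc(O)cc(O)c12`, in an ADME assay on Huh-5-2 cells (Homo sapiens) for cytotoxicity, read by WST assay, with a stated time of 3 days (a higher number here means that more compound is tolerated, a lower number that less compound is tolerated), gives only a limit, > 100000 nM.
Compound 2, `COc1cccc(COc2c(-c3ccccc3)oc3cc(O)cc(O)c3c2=O)c1`, in this assay gives 28000 nM.

Compound 2 holds the only number shown in this assay; the other value shown is a limit. Among the measured compounds shown here, the one measured step, an at least 3.5-fold lower number from compound 1 to compound 2 (0.55 log units; beyond the scatter), runs to compound 2 and is anchored in the limit of > 100000 nM in this assay, at which 1 of the 2 values shown sits.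

Compound 3, `Cc1ccc(COc2c(-c3ccccc3)oc3cc(O)cc(O)c3c2=O)cc1`, has not yet been measured in this assay. It differs from compound 2 in one place: 4-methylphenyl in place of 3-methoxyphenyl on a saturated chain carbon bound to an oxygen on an aromatic ring. No measured step concerns this exchange; the only step shown swaps a 2-chlorophenyl for a 3-methoxyphenyl on that same saturated chain carbon, so it tells how much the group at that position can shift the number, but not in which direction a methyl in place of a methoxy would move it. With nothing pointing either way, compound 3 is expected to land near compound 2, with the step of a 1.1-fold higher number from compound 2 to compound 3 (0.03 log units; within the scatter) staying within the scatter. The estimate for compound 3 in this assay is 30000 nM, with a range from 10000 nM to 90000 nM.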

Compound 3, half-maximal cytotoxic concentration: 40000 nM
For compound 3 the middle estimate is 1.3-fold (0.12 log units) below the measured one; the range from low to high includes it.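

In this assay, 4-methylphenyl in place of 3-methoxyphenyl on a saturated chain carbon bound to an oxygen on an aromatic ring gives a 1.4-fold higher number from compound 2 to compound 3 (0.15 log units; within the scatter), so the two groups cannot be told apart here, although one carries an oxygen and the other only carbon. The exchange of 2-chlorophenyl for 4-methylphenyl gives an at least 2.5-fold lower number from compound 1 to compound 3 (0.39 log units; beyond the scatter), which runs the same way as an at least 3.5-fold lower number from compound 1 to compound 2 (0.55 log units; beyond the scatter), so two different groups now sit on the lower side of 2-chlorophenyl at this position. Compound 1 stands at a limit and not at a number, so both steps from it are bounded on one side only: the limit of > 100000 nM in this assay, at which 1 of the 3 values shown sits.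

From the compounds shown here alone, what remains open is how any of these three groups compares with an unsubstituted phenyl at this position, and so whether the gap to compound 1 belongs to the 2-chlorophenyl or to the other two groups. Also open, going by these compounds, is how the number would respond to an amine or a carboxylic acid on this ring, or to a longer chain between the oxygen and the ring.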